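This account rests on a few compounds, and the source may have more. Where it says the series, first, only, none or still open, it means among the compounds named here.

Measured so far in an ADME assay on BJ cells (Homo sapiens) for cytotoxicity, with a stated time of 72 h; on this read-out higher numbers stand for an effect only at larger amounts of compound and lower numbers for an effect already at smaller amounts:
- Compound 1 `Cc1cc(NC(=O)Nc2ccccc2N)c2ccccc2n1` gives > 25000 nM as a limit
- Compound 2 `Cc1cc(NC(=O)Nc2ccccc2C(C)(C)C)c2ccccc2n1` gives 22000 nM as a number
- Compound 3 `COc1ccccc1NC(=O)Nc1cc(C)nc2ccccc12` gives > 25000 nM as a limit

Compound 3 therefore has a limit and not a number. It sits at the limit of > 25000 nM in this assay, at which 2 of the 3 values shown sit, and has no exact value.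

Compound 4 `Cc1cc(NC(=O)Nc2ccccc2C(F)(F)F)c2ccccc2n1` carries trifluoromethyl in place of methoxy on an aromatic carbon, ortho to a large group: trifluoromethyl in place of methoxy on an aromatic carbon.

The closest evidence is the other group swaps in this set. These are an at least 1.1-fold lower number from compound 1 to compound 2 (0.05 log units; that floor lies within the scatter) and an at least 1.1-fold higher number from compound 2 to compound 3 (0.05 log units; that floor lies within the scatter), while a step that the two limits leave unreadable from compound 1 to compound 3 cannot be sized. None shows a step beyond the scatter, so none is expected in this assay here.

The expected change is an at least 1.0-fold lower number from compound 3 to compound 4 (0.01 log units; that floor lies within the scatter) as an estimate. Compound 4 is estimated at 24000 nM with a range from 13000 nM to 35000 nM and may well return only a limit.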

Compound 4, half-maximal effective concentration in the BJ assay: > 25000 nM
Compound 4 was reported as a limit (the forecaster's own chance of this, stated with the estimate: 60%); middle value at least 1.0-fold (0.01 log units) from the limit.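

Compound 4 returns only a limit in the BJ assay, as the amino and methoxy compounds do: the limit of > 25000 nM in the BJ assay, at which 3 of the 4 values shown sit. For the compounds shown here, in the BJ assay the steps to compound 4 from compounds 1 and 3 cannot be read, and the one readable step is an at least 1.1-fold higher number from compound 2 to compound 4 (0.05 log units; that floor lies within the scatter). In a physicochemical assay for solubility, at pH 7.4 (on this read-out higher numbers stand for higher solubility and lower numbers for lower solubility), compound 3 gives 100 nM and compound 4 gives 3800 nM. The new finding is that trifluoromethyl in place of methoxy on this aromatic carbon leaves the cell read-out at its limit yet changes solubility strongly in the physicochemical assay: the measured solubility of compound 3, 100 nM, and of compound 4, 3800 nM, a 38-fold higher number (1.58 log units; beyond the scatter)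

As far as these compounds go, how far these compounds differ in the BJ assay beyond that limit stays open. So does how a nitrile or a carboxylic acid on this same carbon would behave in the BJ assay and in the physicochemical assay.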